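The source may report more compounds than this note shows. Statements on the series, on what has been measured and on what is new or still open speak of the compounds shown alone.

Measured compounds and their values:

Compound 1, `CCCc1ccc(N2C(=O)NC3(CSC4=C3C(=O)c3ncccc3C4=O)C2=O)cc1`, gives 2 nM.
Compound 2, `O=C1NNC(=O)C2(CSC3=C2C(=O)c2ncccc2C3=O)N1`, gives 48 nM.
Compound 3, `O=C1C2=C(C(=O)c3ncccc31)C1(CS2)NC(=O)N(c2ccc([N+](=O)[O-])cc2)C1=O`, gives 2 nM.

All three were tested in a functional assay on CCRF-SB cells (Homo sapiens) for antiproliferative activity, read by MTT assay, with a stated time of 96 h; on this read-out lower numbers stand for stronger inhibition and higher numbers for weaker inhibition. Compound 3 stands level with compound 1 at the digits shown, and together these two give the lowest numbers of the set. Compound 2, which carries no aryl group at all on the shared core, gives a much higher number than compound 3, a gap that lies well beyond the usual scatter.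

Compound 4, `Cc1ccc(N2C(=O)NC3(CSC4=C3C(=O)c3ncccc3C4=O)C2=O)cc1`, differs from compound 3 in one place: methyl in place of nitro on an aromatic carbon. Among the measured compounds shown here, one measured step bears on this. Going from compound 1 to compound 3 swapped propyl for nitro on the same aromatic carbon, and in this assay that gave no change at the digits printed from compound 1 to compound 3 (within the scatter). Since a propyl group and a nitro group gave the same number there, a methyl group, which is an alkyl chain like propyl only shorter, is expected to behave in the same way. The step from compound 3 to compound 4 is therefore expected to be a 1.3-fold higher number from compound 3 to compound 4 (0.10 log units; within the scatter), with no movement beyond the scatter in either direction. Compound 4 is estimated to give 2.5 nM, in a range from 1 nM to 6 nM.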

Compound 4, half-maximal inhibitory concentration: 20 nM
Compound 4: the middle estimate sits 8.0-fold (0.90 log units) below what was measured, outside the stated range (above it).
By their numbers in this assay, from the lowest: compounds 1 and 3 (each within the scatter of the next); then compound 4; then compound 2.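

Replacing nitro with methyl on the aromatic carbon para to a large group gives a 10-fold higher number from compound 3 to compound 4 (1.00 log units; beyond the scatter) in this assay, so this position is sensitive to the choice of group, which the level values of the propyl and nitro compounds could not reveal. Chain length matters here as well, since shortening propyl to methyl gives a 10-fold higher number from compound 1 to compound 4 (1.00 log units; beyond the scatter), and two alkyl groups at the same place therefore do not behave alike, while propyl and nitro, two very different groups, stay level with each other. Nothing in the data shown explains why methyl stands apart from the other two groups.

With only three groups at this position, the compounds shown cannot tell whether the number changes step by step with chain length or falls off sharply somewhere between methyl and propyl, a question that an ethyl or a butyl group would help to settle. They also leave open how a plain hydrogen, an amine or a carboxylic acid at the same carbon would compare with nitro and propyl.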